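Adding a Methoxy Group to Two Related Cores

A few compounds are considered here, and "the series" means these few. Any claim that something is new, unique, unknown or untested is made for them only; others in the source may bear on it.

Of the compounds shown here, three have been tested in a functional assay for inhibition, with Rattus norvegicus as the target; a higher number here means a weaker inhibitor, a lower number a stronger inhibitor. Compound 1 `CCCCc1cc(OC)c2ccccc2c1OC(C)=O` gives 440 nM. Compound 3 `CCCCc1cc(OC)c2c(OC)cccc2c1OC(C)=O` gives 260 nM; the change from compound 1 to compound 3 is methoxy in place of hydrogen on an aromatic carbon, and it made a 1.7-fold lower number from compound 1 to compound 3 (0.23 log units; within the scatter). Compound 2 `CCc1c(CC)c(OC(C)=O)c2ccccc2c1OC` gives 400 nM; it is built from the same atoms as compound 1, joined differently, and the difference between the two cores is not broken down here. Compound 4 `CCc1c(CC)c(OC(C)=O)c2cc(OC)ccc2c1OC` awaits measurement. The change from compound 2 to compound 4 is methoxy in place of hydrogen on an aromatic carbon. This is the same kind of change as the earlier one, though the surroundings differ: there the methoxy sat ortho to a fused ring and meta to a fused ring, here it sits meta to a fused ring and para to a fused ring. Going by the values given here, the earlier step, a 1.7-fold lower number from compound 1 to compound 3 (0.23 log units; within the scatter), is the only guide. For compound 4 a step of similar size is expected, a 1.3-fold lower number from compound 2 to compound 4 (0.12 log units; within the scatter). Compound 4 is therefore estimated at 300 nM, likely between 120 nM and 800 nM.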

Compound 4, half-maximal inhibitory concentration: 690 nM
Estimate against measurement, compound 4: 2.3-fold (0.36 log units) below, and the stated range covers the measured number.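

Methoxy in place of hydrogen on the core of compound 2 gave a 1.7-fold higher number from compound 2 to compound 4 (0.24 log units; within the scatter) and so ran opposite to the step on the core of compound 1, although each step taken alone stays within the scatter. Set side by side, the two steps differ by more than that scatter: the same change on two cores in this assay, a 1.7-fold lower number (0.23 log units; within the scatter) from compound 1 to compound 3 and a 1.7-fold higher number (0.24 log units; within the scatter) from compound 2 to compound 4, 2.9-fold (0.47 log units) apart, beyond the scatter of two such steps.
So in this series, the result of this change on one core did not carry over to the other, but with only two pairs, and with the methoxy in a different place in each, the effect of the core cannot be separated from that of the position.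

The compounds shown leave open what methoxy would do in the same place on both cores. They also leave open how an amine or an ethoxy group would behave there.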